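From furan-2-yl to 4-chlorophenyl on the shared core

The compounds below may be only part of what the source reports. "The series", "measured", "known", "first", "only" and "open" are said of these compounds alone.

Measured in a functional assay on HeLa cells (Homo sapiens) for cytotoxicity, read by ELISA, with a stated time of 4 days; a higher number here means a weaker inhibitor, a lower number a stronger inhibitor:
- compound 1 `Cc1ccsc1-c1cc(-c2ccco2)cc(-c2ccccc2Cl)n1`: 24000 nM
- compound 2 `Cc1ccsc1-c1cc(-c2ccco2)cc(-c2ccc(Cl)cc2)n1`: 24500 nM
- compound 3 `Cc1ccsc1-c1cc(-c2ccoc2)cc(-c2ccco2)n1`: 30500 nM

The three compounds sit close together. In this assay compound 3 gives 30500 nM, and this value lies within the scatter of the values of compound 1 and compound 2, so it stands apart from neither.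

The next compound is compound 4 `Cc1ccsc1-c1cc(-c2ccoc2)cc(-c2ccc(Cl)cc2)n1`, which keeps the furan-3-yl group of compound 3 and differs from it at one place: 4-chlorophenyl in place of furan-2-yl on an aromatic carbon. The exchange lies on the carbon next to the ring nitrogen.

For the measured compounds named here, only one measured step bears on this, and only indirectly. Moving the chlorine of the chlorophenyl group gave a 1.0-fold higher number from compound 1 to compound 2 (0.01 log units; within the scatter), so that change did not register. Going by the values given here, no measured step exchanges furan-2-yl for 4-chlorophenyl directly. The nearest evidence is compound 2 at 24500 nM, which already carries 4-chlorophenyl at that place, though with furan-2-yl where compound 4 has furan-3-yl.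

No change beyond the scatter is therefore expected, and no firm direction. The expected step is a 1.2-fold lower number from compound 3 to compound 4 (0.09 log units; within the scatter). For compound 4 the estimated value is 25000 nM, with an expected range from 12000 nM to 50000 nM.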

Compound 4, half-maximal inhibitory concentration: 17400 nM
The estimate for compound 4 lay 1.4-fold (0.16 log units) above the measured number; low and high end bracket the measured number.
By their numbers in this assay, from the lowest: compounds 4, 1, 2 and 3 (each within the scatter of the next).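

At the place next to the ring nitrogen, the exchange of furan-2-yl for 4-chlorophenyl can now be read directly in this assay and gives a 1.8-fold lower number from compound 3 to compound 4 (0.24 log units; within the scatter); a five-membered aromatic ring with its one hydrogen-bond acceptor thus gives way to a larger six-membered ring of carbon only, with no change beyond the scatter. For the compounds shown here, the other ring position, now read for the first time with 4-chlorophenyl held in place, gives a 1.4-fold lower number from compound 2 to compound 4 (0.15 log units; within the scatter) for furan-3-yl in place of furan-2-yl, and this too stays within the scatter. No measured evidence is available to account for either step.

Both groups exchanged at this place are aromatic rings, so the compounds shown leave open whether an amine, a carboxylic acid or a longer alkyl chain on the same carbon would move the number beyond the scatter. Also open, from the compounds shown here alone, is what an amide would do in place of the 3-methylthiophen-2-yl group, which all four compounds share.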